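The compounds below may be only part of what the source reports. "The series", "measured", "known", "first", "only" and "open" are said of these compounds alone.

Working notes on the series. Among the measured compounds shown here, in a functional assay on RD cells (Homo sapiens) for inhibition, read by MTT assay, with a stated time of 72 h (a higher number here means a weaker inhibitor, a lower number a stronger inhibitor), compound 2, with the structure `CCN1C(=O)N(CC)C2C1NC(=O)N2/N=C/C=C/c1ccccc1`, gives 2020 nM; among the values shown this is the only number. Compound 1, with the structure `CSC1=NC2C(N(C)C(=O)N2C)N1/N=C/C=C/c1ccccc1[N+](=O)[O-]`, is recorded in this assay only as > 100000 nM, which is a limit of the assay and not a number, as noted in the limit of > 100000 nM in this assay, at which 1 of the 2 values shown sits. Compound 1 and compound 2 differ at more than one place, so their values show only that one sits at the limit and the other gives a number.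

Compound 3, with the structure `CCN1C(=O)N(CC)C2C1NC(=O)N2/N=C/C=C/c1ccccc1[N+](=O)[O-]`, has not yet been measured in this assay. It differs from compound 2 by nitro in place of hydrogen on an aromatic carbon, in words nitro in place of hydrogen on an aromatic carbon; read one bond further out, phenyl becomes 2-nitrophenyl. For the measured compounds named here, no measured step of this kind exists. Compound 1, which also carries a 2-nitrophenyl, sits at the limit > 100000 nM. Compound 3 is therefore expected to be a weaker inhibitor than compound 2, by a step of a 3.0-fold higher number from compound 2 to compound 3 (0.47 log units; beyond the scatter) that may exceed the scatter, and its value in this assay is estimated at 6000 nM, with a range from 1500 nM to 30000 nM.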

Compound 3, half-maximal inhibitory concentration: 1930 nM
Compound 3: the middle estimate sits 3.1-fold (0.49 log units) above what was measured; low and high end bracket the measured number.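

In this assay, the change from phenyl to 2-nitrophenyl now has a measured step, which reads a 1.0-fold lower number from compound 2 to compound 3 (0.02 log units; within the scatter). The 2-nitrophenyl group therefore does not by itself go with a limit of the assay, as compound 3 carries this group and gives a number. Compound 1 is now the only compound recorded as a limit, which is not a number: the limit of > 100000 nM in this assay, at which 1 of the 3 values shown sits.

Compound 1 and compound 3 differ at more than one place, so the compounds shown cannot say which of those differences goes with the limit, and no single change on the shared core has yet been tied to it. It also remains open whether this aromatic carbon, ortho to a large group, accepts other substituents as it accepts nitro, for example an amine or a carboxylic acid in place of the same hydrogen, or whether nitro is simply one case among the few shown here.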